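The compounds below may be only part of what the source reports. "The series", "measured", "known", "first", "only" and "open" are said of these compounds alone.

In a physicochemical assay for solubility, read by HPLC, in phosphate buffer, with a stated time of 20 min, at pH 9.0 (a higher number here means a more soluble compound, a lower number a less soluble compound), compound 1 `CCOC(=O)C1=C[C@@H](OC(CC)CC)[C@H](NC(C)=O)[C@@H](N/C(C)=N/O)C1` gives 23000000 nM. Compound 2 `CCOC(=O)C1=C[C@@H](OC(CC)CC)[C@H](NC(C)=O)[C@@H](NC(C)=N)C1` gives > 50000000 nM, which is a limit of the assay and not a number. Compound 3 `CCOC(=O)C1=C[C@@H](OC(CC)CC)[C@H](NC(C)=O)[C@@H](NC(=N)N)C1` carries amino in place of methyl on a carbon with a double bond to nitrogen. Among the compounds with values here, the only measured step, an at least 2.1-fold higher number from compound 1 to compound 2 (0.33 log units; beyond the scatter), involves a different change, on an amine nitrogen, and it is only a weak guide here. Within the data shown here, no measured step shows this swap, so no clear shift is expected in this assay. The expected step is a number no higher from compound 2 to compound 3 (the limit leaves the size open), none beyond the scatter. For compound 3 the estimated value is 50000000 nM, with an expected range from 25000000 nM to 100000000 nM.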

Compound 3, solubility: > 50000000 nM
Compound 3 gave a limit, no number (the forecaster's own chance of this, stated with the estimate: 65%); the middle value lies on the limit itself.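

In this assay compound 3 gives > 50000000 nM as a limit of the assay and not a number. The step from compound 2 to compound 3 cannot be read, so amino in place of methyl has no measured size here. Compound 1 still gives a readable comparison, an at least 2.1-fold higher number from compound 1 to compound 3 (0.33 log units; beyond the scatter), so a second group on the amine nitrogen stands apart from compound 1, and the readings end at one ceiling: the limit of > 50000000 nM in this assay, at which 2 of the 3 values shown sit.

From the compounds shown here alone, how far compound 2 and compound 3 lie from each other stays open. Also open, going by these compounds, is whether a longer chain or a carboxylic acid in place of amino would reach the same limit.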